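Swapping sulfur for oxygen on the ring nitrogen of a second core

This account rests on a few compounds, and the source may have more. Where it says the series, first, only, none or still open, it means among the compounds named here.

Compound 1 `NC(=O)c1c(NC(=O)c2ccccc2F)sc2c1CCN(C(=S)Nc1ccccc1Cl)C2` and compound 2 `NC(=O)c1c(NC(=O)c2ccccc2F)sc2c1CCN(C(=O)Nc1ccccc1Cl)C2` share a core and differ only where (a group of 10 heavy atoms (7 carbon, 1 nitrogen, 1 oxygen, 1 chlorine; one six-membered aromatic ring of carbon only) in place of a group of 10 heavy atoms (7 carbon, 1 nitrogen, 1 sulfur, 1 chlorine; one six-membered aromatic ring of carbon only), on an amine nitrogen in a ring). In a functional assay on MKN-74 cells (Homo sapiens) for antiproliferative activity, with a stated time of 24 h (on this read-out higher numbers stand for weaker inhibition and lower numbers for stronger inhibition), compound 1 gives 11100 nM and compound 2 gives 49600 nM, so the change made a step of a 4.5-fold higher number from compound 1 to compound 2 (0.65 log units; beyond the scatter). Compound 3 `NC(=O)c1c(NC(=O)c2cccc([N+](=O)[O-])c2)sc2c1CCN(C(=S)Nc1ccccc1Cl)C2` carries a different core, differing from compound 1 where (3-nitrophenyl in place of 2-fluorophenyl on a carbonyl carbon); in this assay compound 3 gives 8850 nM, a step of a 1.3-fold lower number from compound 1 to compound 3 (0.10 log units; within the scatter). Compound 4 `NC(=O)c1c(NC(=O)c2cccc([N+](=O)[O-])c2)sc2c1CCN(C(=O)Nc1ccccc1Cl)C2` differs from compound 3 where (a group of 10 heavy atoms (7 carbon, 1 nitrogen, 1 oxygen, 1 chlorine; one six-membered aromatic ring of carbon only) in place of a group of 10 heavy atoms (7 carbon, 1 nitrogen, 1 sulfur, 1 chlorine; one six-membered aromatic ring of carbon only), on an amine nitrogen in a ring), the same change as before at the same place. Within the data shown here, compound 4 is expected to show a step of a 4.5-fold higher number from compound 3 to compound 4 (0.66 log units; beyond the scatter) in this assay, because the step of a 4.5-fold higher number from compound 1 to compound 2 (0.65 log units; beyond the scatter) is the only measured instance of this change. The estimate for compound 4 is 40000 nM, within 15000 nM to 100000 nM.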

Compound 4, half-maximal inhibitory concentration: 22700 nM
Estimate against measurement, compound 4: 1.8-fold (0.25 log units) above; the measured number falls inside the stated range.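

In this assay, swapping sulfur for oxygen again gives a higher number on the second core, a 2.6-fold higher number from compound 3 to compound 4 (0.41 log units; beyond the scatter), and its size does not differ from the earlier step beyond the scatter: the same change on two cores in this assay, a 4.5-fold higher number (0.65 log units; beyond the scatter) from compound 1 to compound 2 and a 2.6-fold higher number (0.41 log units; beyond the scatter) from compound 3 to compound 4, 1.7-fold (0.24 log units) apart, within the scatter of two such steps

The other change, 3-nitrophenyl in place of 2-fluorophenyl, gives a 2.2-fold lower number from compound 2 to compound 4 (0.34 log units; beyond the scatter), and it too agrees with its partner step: the same change on two cores in this assay, a 1.3-fold lower number (0.10 log units; within the scatter) from compound 1 to compound 3 and a 2.2-fold lower number (0.34 log units; beyond the scatter) from compound 2 to compound 4, 1.7-fold (0.24 log units) apart, within the scatter of two such steps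

This shows that both changes carried over between these two pairs of compounds in this assay, but two pairs are too few to make a general rule, and they do not show why the numbers move.

On these data alone, it remains open whether the sulfur-to-oxygen swap behaves the same way when the carbonyl carbon carries a different group, such as a longer alkyl chain or a phenyl ring bearing a carboxylic acid.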